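Aryl variation on the ring amide nitrogen, indolyl analogue

The source may hold more compounds than are shown below. What is called first, only, known or untested is meant among the compounds shown, and "the series" means these compounds.

Measured compounds:
compound 1 `COc1cc(OC)cc(N2NC3=CC[C@@H](OC)O[C@@]3(c3ccccc3)CCC2=O)c1`, 2400 nM in a functional assay on DU-145 cells (Homo sapiens) for cytotoxicity, read by sulforhodamine B assay, with a stated time of 48 h; a lower number here means a stronger inhibitor, a higher number a weaker inhibitor
compound 2 `CO[C@@H]1CC=C2NN(c3cc(Cl)cc(Cl)c3)C(=O)CC[C@]2(c2ccccc2)O1`, 8460 nM in this assay
compound 3 `CO[C@@H]1CC=C2N(c3ccc(C)cc3)C(=O)C[C@]2(c2ccccc2)O1`, 4400 nM in this assay

Compound 3 holds the second highest of the three numbers in this assay. Its nearest neighbour is compound 1, whose number is lower by an amount within the scatter; compound 2 lies furthest, with a higher number, yet that gap too stays within the scatter. Nothing in these three values orders compound 3 against the others.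

Compound 4 `CO[C@@H]1CC=C2N(c3c[nH]c4ccccc34)C(=O)C[C@]2(c2ccccc2)O1` differs from compound 3 in a single place: 1H-indol-3-yl in place of 4-methylphenyl on an amide-type nitrogen in a ring. Going by the values given here, the only measured step that touches the same kind of change is the exchange of the aryl group on the ring amide nitrogen, a 3.5-fold higher number from compound 1 to compound 2 (0.55 log units; beyond the scatter), although that pair sits on a different core from compound 3 and compound 4. Among the compounds with values here, that step was modest, and no measured pair covers an indolyl group or a hydrogen-bond donor at this position.

On that basis compound 4 is expected to stay close to compound 3, with a step of a 1.1-fold lower number from compound 3 to compound 4 (0.04 log units; within the scatter) that is not expected to exceed the scatter. The estimate for compound 4 in this assay is 4000 nM, between 1500 nM and 12000 nM.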

Compound 4, half-maximal inhibitory concentration: 7330 nM
The estimate for compound 4 lay 1.8-fold (0.26 log units) below the measured number; the measured number falls inside the stated range.
By their numbers in this assay, from the lowest: compounds 1, 3, 4 and 2 (each within the scatter of the next, the first and the last beyond it).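

In this assay the exchange of 4-methylphenyl for 1H-indol-3-yl on the amide-type nitrogen in a ring gives a 1.7-fold higher number from compound 3 to compound 4 (0.22 log units; within the scatter) and so shows that, on the core shared by compound 3 and compound 4, an aryl group with a five-membered aromatic ring and a hydrogen-bond donor can stand at this position without a step that can be told from the scatter. Going by these compounds alone, the only earlier aryl exchange, a 3.5-fold higher number from compound 1 to compound 2 (0.55 log units; beyond the scatter), lies beyond the scatter but sits on a different core, so the two steps do not combine into one trend for this position. No supporting measurement bears on this result.

From the compounds shown here alone, it remains open whether the hydrogen-bond donor of the 1H-indol-3-yl group plays any part in this number, which 1-methylindol-3-yl at the same place would test. Also open, going by these compounds, is whether a carboxylic acid or an aminomethyl group on the aryl ring, or the 3,5-dichlorophenyl and 3,5-dimethoxyphenyl groups on the core of compound 3, would move the number beyond the scatter.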